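This account rests on a few compounds, and the source may have more. Where it says the series, first, only, none or still open, it means among the compounds named here.

Compound 1 `Cc1nc(S(C)(=O)=O)ccc1Oc1ncnc(OC2CCN(C(=O)O[C@H](C)CF)CC2)c1F`: 196 nM
Compound 2 `Cc1nc(S(C)(=O)=O)ccc1Oc1ncnc(OC2CCN(C(=O)OC3(C(F)(F)F)COC3)CC2)c1F`: 29.3 nM
Compound 3 `Cc1nc(S(C)(=O)=O)ccc1Oc1ncnc(OC2CCN(C(=O)SC3(C)CC3)CC2)c1F`: 13.2 nM

All three were tested in a functional assay on isolated protein for inhibition of Glucose-dependent insulinotropic receptor (Homo sapiens), read by HTRF and cAMP accumulation; a higher number here means that more compound is needed for the effect, a lower number that less compound is needed. Compound 3 gives the lowest number of the three, as the steps of a 2.2-fold lower number from compound 2 to compound 3 (0.35 log units; beyond the scatter) and a 15-fold lower number from compound 1 to compound 3 (1.17 log units; beyond the scatter) show. Compound 4 `Cc1nc(S(C)(=O)=O)ccc1Oc1ncnc(OC2CCN(C(=S)OC(C)C)CC2)c1F` is the next compound; here (a group of 6 heavy atoms (4 carbon, 1 oxygen, 1 sulfur; no ring) in place of a group of 7 heavy atoms (5 carbon, 1 oxygen, 1 sulfur; one three-membered non-aromatic ring of carbon only), on an amine nitrogen in a ring). The two steps that ended at compound 3, a 15-fold lower number from compound 1 to compound 3 (1.17 log units; beyond the scatter) and a 2.2-fold lower number from compound 2 to compound 3 (0.35 log units; beyond the scatter), both exchanged the group attached to the carbonyl carbon and both lowered the number, the first step by a large amount. Compound 4 undoes that exchange in part, giving up the three-membered ring and the sulfur on the carbonyl carbon, so a higher number is expected, of modest size, with a 4.5-fold higher number from compound 3 to compound 4 (0.66 log units; beyond the scatter). For compound 4 the estimate is 60 nM, in a range from 20 nM to 250 nM.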

Compound 4, half-maximal effective concentration: 69.9 nM
Compound 4: middle estimate off by 1.2-fold (0.07 log units), on the low side, and the stated range covers the measured number.
By their numbers in this assay, from the lowest: compound 3; then compound 2; then compound 4; then compound 1.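

In this assay, keeping the sulfur and oxygen counts but losing the three-membered ring gives a 5.3-fold higher number from compound 3 to compound 4 (0.72 log units; beyond the scatter), so a ring-free, sulfur-bearing group on the amine nitrogen in the ring still works, though less well. That group also compares well with the ring-free, fluorine-bearing group, with a 2.8-fold lower number from compound 1 to compound 4 (0.45 log units; beyond the scatter), but falls short of the oxetane group, with a 2.4-fold higher number from compound 2 to compound 4 (0.38 log units; beyond the scatter). No measurement here explains these shifts.

Compound 4 loses the ring and also carries its sulfur differently, so these two changes cannot be separated. On these data alone, how an amine or a longer chain in this group would behave also stays open.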